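Isopropyl Replaced by a 2-Aminoethyl Chain

A few compounds are considered here, and "the series" means these few. Any claim that something is new, unique, unknown or untested is made for them only; others in the source may bear on it.

In an assay on isolated protein for inhibition of seed linoleate 13S-lipoxygenase-1 (Glycine max) (on this read-out lower numbers stand for stronger inhibition and higher numbers for weaker inhibition), the measured compounds give:
compound 1 `CC(C)CNCc1c(O)ccc2ccc(=O)oc12`: 47000 nM
compound 2 `O=c1ccc2ccc(O)c(CNCc3ccccc3)c2o1`: 44000 nM
compound 3 `NCCNCc1c(O)ccc2ccc(=O)oc12`: >> 1000000 nM, which is a limit of this assay and not a number

Compound 1 has the highest of the two numbers, with compound 2 nearest: the step of a 1.1-fold lower number from compound 1 to compound 2 (0.03 log units; within the scatter) is within the scatter, so the two cannot be told apart. Compound 3 sits at the limit (the limit of >> 1000000 nM in this assay, at which 1 of the 3 values shown sits). The step of an at least 21-fold higher number from compound 1 to compound 3 (1.32 log units; beyond the scatter) is large, and the step of an at least 22-fold higher number from compound 2 to compound 3 (1.35 log units; beyond the scatter) matches it.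

Compound 4 `NCCCNCc1c(O)ccc2ccc(=O)oc12` differs from compound 1 by 2-aminoethyl in place of isopropyl on a saturated chain carbon bound to an amine nitrogen. This is the same kind of change as the step to compound 3, only with the chain one carbon longer. Since the step of an at least 21-fold higher number from compound 1 to compound 3 (1.32 log units; beyond the scatter) was large and ended at a limit, a similarly large weakening is expected here, and it is quite possible that compound 4 will also be recorded only as a limit. Compound 4 is therefore expected to show the step of a 13-fold higher number from compound 1 to compound 4 (1.11 log units; beyond the scatter). For compound 4 the estimate is 600000 nM, with a range from 150000 nM to 3000000 nM.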

Compound 4, half-maximal inhibitory concentration: >> 1000000 nM
Compound 4 ended at the assay's limit; the forecaster's own chance of this, stated with the estimate: 60%; at least 1.6-fold (0.22 log units) between middle value and limit.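

Lengthening the chain by one carbon does not bring the inhibition back: in this assay, 2-aminoethyl in place of isopropyl gives an at least 21-fold higher number from compound 1 to compound 4 (1.32 log units; beyond the scatter), and 2-aminoethyl in place of phenyl gives an at least 22-fold higher number from compound 2 to compound 4 (1.35 log units; beyond the scatter). The large loss seen with the aminomethyl group of compound 3 is therefore not confined to that one chain length, and neither of the two chains ending in an amine goes against this. Compound 3 and compound 4 both stand at a limit and not at a number, so the step between them cannot be read and any effect of the extra carbon stays hidden: the limit of >> 1000000 nM in this assay, at which 2 of the 4 values shown sit.

The compounds shown leave open whether the amine at the chain end is what goes with the loss, since a chain of similar length ending in a hydroxyl group or a carboxylic acid would be needed to separate the end group from the chain itself. They also leave open whether a still longer chain ending in an amine, or a chain ending in a dimethylamino group, would stay at this limit.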